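The source may hold more compounds than are shown below. What is called first, only, known or untested is meant among the compounds shown, and "the series" means these compounds.

Of the compounds shown here, three of a shared core have been measured. Compound 1 `O=C(Nn1c(-c2cccc([N+](=O)[O-])c2)nc2c(-c3ccc(Cl)cc3)n[nH]c2c1=O)c1cccnc1` gives 15.1% in a functional assay on HT-29 cells (Homo sapiens) for cytotoxicity, read by sulforhodamine B assay, with a stated time of 2 days, tested at 100 uM; a lower number here means less inhibition, a higher number more inhibition at the concentration tested (going by the name of the read-out); compound 2 `COc1cccc(-c2nc3c(-c4ccc(Cl)cc4)n[nH]c3c(=O)n2NC(=O)c2ccncc2)c1` gives 46% in this assay; compound 3 `O=C(Nn1c(-c2cccc([N+](=O)[O-])c2)nc2c(-c3ccc(F)cc3)n[nH]c2c1=O)c1cccnc1` gives 24.7% in this assay. Compound 3 thus stands second highest of the three, within the scatter of compound 1 and beyond it below compound 2. For the measured compounds named here, the one step measured in one place, a number 9.6 percentage points higher from compound 1 to compound 3 (within the scatter), is within the scatter. Compound 4 `O=C(Nn1c(-c2cccc([N+](=O)[O-])c2)nc2c(-c3ccco3)n[nH]c2c1=O)c1cccnc1` differs from compound 3 by furan-2-yl in place of 4-fluorophenyl on an aromatic carbon. Going by the values given here, no measured step touches this ring, so the only guide is that the one known change at this place moved little. Compound 4 is therefore expected to show a number 2.3 percentage points higher from compound 3 to compound 4 (within the scatter), with an estimate of 27% and a range from 10% to 50%.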

Compound 4, a percentage reported as inhibition, at one concentration (the size of the read-out at that concentration, not a potency): 11.7%
Beside the measured number, compound 4's estimate is 15.3 percentage points above it; the measured number falls inside the stated range.
By their numbers in this assay, from the lowest: compounds 4, 1 and 3 (each within the scatter of the next, the first and the last beyond it); then compound 2.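

This position now shows a step beyond the scatter: in this assay, the change to furan-2-yl gives a number 13 percentage points lower from compound 3 to compound 4 (beyond the scatter). Measured against the chlorinated partner, the same ring gives a number 3.4 percentage points lower from compound 1 to compound 4 (within the scatter), so whether this change registers depends on which halogenated phenyl it replaces. No evidence is available on the cause of this result. Still open, from the compounds shown here alone, is how this position would respond to a group other than an aromatic ring, such as an amine or a longer alkyl chain, and whether a different five-membered aromatic ring, such as thiophene, would read like furan-2-yl.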